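A few compounds are considered here, and "the series" means these few. Any claim that something is new, unique, unknown or untested is made for them only; others in the source may bear on it.

Measured compounds:
compound 1, `CC1=CC[C@@H]([C@@](C)(O)CCCC(C)(C)NC(=S)N/N=C\c2ccccc2)CC1` — in a functional assay on PCO3 cells (Homo sapiens) for cytotoxicity, read by sulforhodamine B assay (a higher number here means a weaker inhibitor of growth, a lower number a stronger inhibitor of growth), compound 1 gives 36200 nM
compound 2, `CC1=CC[C@@H]([C@@](C)(O)CCCC(C)(C)NC(=S)N/N=C\c2ccc(O)cc2)CC1` — compound 2 gives 13900 nM
compound 3, `CC1=CC[C@@H]([C@@](C)(O)CCCC(C)(C)NC(=S)N/N=C\c2ccc(N(C)C)cc2)CC1` — compound 3 gives > 100000 nM, which is a limit of this assay rather than a number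

Compound 3 stands at the high end of the three. Its value is only a limit (the limit of > 100000 nM in this assay, at which 1 of the 3 values shown sits), so a range is all that is known for it. The steps leading to it are an at least 2.7-fold higher number from compound 1 to compound 3 (0.44 log units; beyond the scatter) and an at least 7.1-fold higher number from compound 2 to compound 3 (0.85 log units; beyond the scatter), while a 2.6-fold lower number from compound 1 to compound 2 (0.42 log units; beyond the scatter) shows the hydroxy pulling the number the other way. Compound 4, `CC1=CC[C@@H]([C@@](C)(O)CCCC(C)(C)NC(=S)N/N=C\c2ccccc2Cl)CC1`, differs from compound 3 by 2-chlorophenyl in place of 4-(dimethylamino)phenyl on a carbon with a double bond to nitrogen. Taking away the dimethylamino undoes the change behind an at least 2.7-fold higher number from compound 1 to compound 3 (0.44 log units; beyond the scatter), so compound 4 is expected to move back toward the figure of compound 1, 36200 nM. Among the measured compounds shown here, the chlorine on the ring has no counterpart among the measured compounds, so its own contribution is unknown. The step of an at least 3.3-fold lower number from compound 3 to compound 4 (0.52 log units; beyond the scatter) is therefore expected to lower the number. For compound 4 the estimate in this assay is 30000 nM, with a range from 10000 nM to 100000 nM.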

Compound 4, concentration for total growth inhibition: > 100000 nM
Compound 4: only a limit was reported (the forecaster's own chance of this, stated with the estimate: 20%); at least 3.3-fold (0.52 log units) between middle value and limit.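

In this assay, the aromatic ring on the carbon with a double bond to nitrogen loses growth inhibition with a chloro group as well as with dimethylamino: chloro in place of hydrogen gives an at least 2.7-fold higher number from compound 1 to compound 4 (0.44 log units; beyond the scatter), and 2-chlorophenyl in place of 4-hydroxyphenyl gives an at least 7.1-fold higher number from compound 2 to compound 4 (0.85 log units; beyond the scatter). Among the ring groups shown, only the hydroxy of compound 2 lowers the number relative to the unsubstituted compound 1, while compound 3 and compound 4 both go against any general gain from substitution. Compound 3 and compound 4 each rest on a limit, so the step between them cannot be read: the limit of > 100000 nM in this assay, at which 2 of the 4 values shown sit.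

As far as these compounds go, how far compound 3 and compound 4 lie beyond that limit remains open. Also open, from the compounds shown here alone, is whether a methoxy group or a carboxylic acid on the ring would follow the hydroxy of compound 2 or the chloro of compound 4.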